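The compounds below may be only part of what the source reports. "The series", "measured", "known", "first", "only" and "open" are said of these compounds alone.

Working notes on the series. Going by the values given here, in a functional assay on HepG2 cells (Homo sapiens) for antiproliferative activity, read by spectrophotometry, with a stated time of 2 days (a lower number here means a stronger inhibitor of growth, a higher number a weaker inhibitor of growth), compound 1 `CC(=O)N1CCN(c2ccc(Nc3ncc(C(F)(F)F)c(N4Cc5cccc(N(C)S(C)(=O)=O)c5C4)n3)cc2)CC1` gives 1400 nM, the only true number so far. Compound 2 `COc1ccc(C(F)(F)F)cc1Nc1ncc(C(F)(F)F)c(N2Cc3cccc(N(C)S(C)(=O)=O)c3C2)n1` reads > 30000 nM, which is a limit of the assay and not a number.

Compound 3 `COc1cc(N2CCN(C(C)=O)CC2)ccc1Nc1ncc(C(F)(F)F)c(N2Cc3cccc(N(C)S(C)(=O)=O)c3C2)n1` is compound 1 with a single change: methoxy in place of hydrogen on an aromatic carbon. Among the compounds with values here, no measured pair isolates this methoxy in place of hydrogen. Compound 2 also carries a methoxy, but it lacks the 4-acetylpiperazin-1-yl group and cannot serve as a direct comparison.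

The expectation therefore rests on compound 1 at 1400 nM, with no shift beyond the scatter expected in this assay and no direction favoured. The expected step of no change at the digits printed from compound 1 to compound 3 (within the scatter) is small. For compound 3 the estimate is 1400 nM, with an expected range of 450 nM to 4500 nM.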

Compound 3, concentration for 50% growth inhibition: 3800 nM
The estimate for compound 3 lay 2.7-fold (0.43 log units) below the measured number; low and high end bracket the measured number.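

In this assay the series now has its first pair that isolates one change: methoxy in place of hydrogen, on the aromatic carbon ortho to a large group and meta to the 4-acetylpiperazin-1-yl group, gives a 2.7-fold higher number from compound 1 to compound 3 (0.43 log units; beyond the scatter). This position therefore accepts a methoxy at a modest cost in growth inhibition, and compound 3 still gives a true number, 3800 nM, and not a limit of the assay. Nothing shown gives a cause for this step.

From the compounds shown here alone, only hydrogen and methoxy are seen at this position, so it stays open whether a fluorine, a hydroxyl or an amine there would give a higher or a lower number than compound 1. Also open, going by these compounds, is whether the methoxy step would hold with another group in place of the 4-acetylpiperazin-1-yl group.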